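Chain length and terminal group in a pyridazinone series

The source may hold more compounds than are shown below. What is called first, only, known or untested is meant among the compounds shown, and "the series" means these compounds.

Measured compounds:
compound 1 `CC/N=C(/NC#N)NCCCn1nc(-c2ccccc2)ccc1=O` gives 62.9% in a functional assay on the whole organism with Rattus norvegicus as the target, at a dose of 100 mg/kg; a lower number here means less inhibition, a higher number more inhibition at the dose given (going by the name of the read-out)
compound 2 `C/N=C(\S)NCCCCn1nc(-c2ccccc2)ccc1=O` gives 87.1% in this assay
compound 3 `C/N=C(\S)NCCCCCCn1nc(-c2ccccc2)ccc1=O` gives 22.2% in this assay

Compound 2 stands highest of the three, compound 3 lowest, and compound 3 is separated from compound 1 by a number 40.7 percentage points lower from compound 1 to compound 3 (beyond the scatter) and from compound 2 by a number 64.9 percentage points lower from compound 2 to compound 3 (beyond the scatter). The two cores of compound 2 and compound 3 differ by a group of 7 heavy atoms (4 carbon, 2 nitrogen, 1 sulfur; no ring) in place of a group of 5 heavy atoms (2 carbon, 2 nitrogen, 1 sulfur; no ring), on a saturated chain carbon, four bonds along the chain from an aromatic nitrogen.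

From compound 2 to compound 1 the change is a group of 8 heavy atoms (4 carbon, 4 nitrogen; no ring) in place of a group of 6 heavy atoms (3 carbon, 2 nitrogen, 1 sulfur; no ring), on a saturated chain carbon, three bonds along the chain from an aromatic nitrogen, and it made a step of a number 24.2 percentage points lower from compound 2 to compound 1 (beyond the scatter). Compound 4 `CC/N=C(/NC#N)NCCCCCn1nc(-c2ccccc2)ccc1=O` is not yet measured; it differs from compound 3 by a group of 8 heavy atoms (4 carbon, 4 nitrogen; no ring) in place of a group of 6 heavy atoms (3 carbon, 2 nitrogen, 1 sulfur; no ring), on a saturated chain carbon, five bonds along the chain from an aromatic nitrogen. This is the same kind of change as that from compound 2 to compound 1, but not the same: it sits five bonds along the chain from the aromatic nitrogen rather than three.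

For compound 4 a step of a number 0.2 percentage points lower from compound 3 to compound 4 (within the scatter) is expected, smaller than the earlier one because compound 3 already stands low at 22.2%, and a full repeat of a number 24.2 percentage points lower from compound 2 to compound 1 (beyond the scatter) is not assumed from this starting point. Compound 4 is estimated at 22%, between 5% and 48%.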

Compound 4, a percentage reported as inhibition, in the whole organism at one dose (the size of the read-out at that dose, not a potency): 48.2%
Estimate against measurement, compound 4: 26.2 percentage points below; measured number outside the range, above it.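

In this assay, placing the group of 8 heavy atoms (4 carbon, 4 nitrogen; no ring) where the group of 6 heavy atoms (3 carbon, 2 nitrogen, 1 sulfur; no ring) stood, five bonds along the chain from an aromatic nitrogen, gives a step of a number 26 percentage points higher from compound 3 to compound 4 (beyond the scatter). The earlier step of this kind ran in the opposite direction, so neither its size nor its sign carries from one core to the other: the same change on two cores in this assay, a number 24.2 percentage points lower (beyond the scatter) from compound 2 to compound 1 and a number 26 percentage points higher (beyond the scatter) from compound 3 to compound 4, 50.2 percentage points apart, beyond the scatter of two such steps

With a single pair on each core, this does not show whether the reversal follows from the place of the change, the starting core or both, and it gives no rule for a further core.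

Still open, on these data alone, is how the two terminal groups compare when they sit at the same place on one chain. Also open, as far as these compounds go, is whether a terminal amine, a carboxylic acid or a longer chain would follow either step in this assay.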